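Swapping chloropyridine for methylpyridine on the shared core

This account rests on a few compounds, and the source may have more. Where it says the series, first, only, none or still open, it means among the compounds named here.

Values in a physicochemical assay for lipophilicity, read by HPLC, at pH 7.4 (a lower number here means a more polar compound, a higher number a more lipophilic compound), for the measured compounds
Compound 1 `COc1cc2oc(=O)n(CCC(=O)O)c2cc1Cl` gives "not determined" (no result reported)
Compound 2 `C[C@@H](Oc1cc2oc(=O)n(CCC(=O)O)c2cc1Cl)c1ccc(Cl)cn1` gives 2.65
Compound 3 `C[C@@H](Oc1cc2onc(CCC(=O)O)c2cc1Cl)c1ccccn1` gives 1.99

Of the compounds with a number, compound 2 stands highest at 2.65 in this series. Compound 3 reads lower at 1.99 by a gap beyond the scatter, while compound 1 offers no number to compare. The account now turns to compound 4 `Cc1cccc([C@@H](C)Oc2cc3oc(=O)n(CCC(=O)O)c3cc2Cl)n1` which differs from compound 2 in a single group. It carries 6-methylpyridin-2-yl in place of 5-chloropyridin-2-yl on a saturated chain carbon bound to an oxygen on an aromatic ring and a saturated chain carbon. Within the data shown here, no measured pair differs in one place only, so no measured step can guide this change, and the expectation is an uncertain one. A small fall in this assay is expected, within or close to the scatter. The estimated step of a number 0.25 log units lower from compound 2 to compound 4 (within the scatter) would therefore be modest. For compound 4 the expected value is 2.4 with an estimated range from 2.05 to 2.75 on this scale.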

Compound 4, distribution coefficient: 2.12
Compound 4: the middle estimate sits 0.28 log units above what was measured; low and high end bracket the measured number.
By their numbers in this assay, from the lowest: compounds 3 and 4 (each within the scatter of the next); then compound 2.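

Among these compounds, at the saturated chain carbon bound to an oxygen on an aromatic ring and a saturated chain carbon, compound 4 gives the first comparison in this assay that differs in one place only: 6-methylpyridin-2-yl in place of 5-chloropyridin-2-yl brings a number 0.53 log units lower from compound 2 to compound 4 (beyond the scatter) on the shared core. The read-out is thus not indifferent to which of these two groups sits here, although both hold the same count of heavy atoms and each is a six-membered aromatic ring with one hetero atom. Nothing on hand accounts for this step.

The swap changes both the substituent and its place on the pyridine, and the compounds shown cannot separate the two. A 5-methylpyridin-2-yl or an unsubstituted pyridin-2-yl on the shared core would part them, whereas compound 3 differs from compound 4 in more than one place.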